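A Methyl Next to the Ring Nitrogen: Growth Inhibition Compared

This account rests on a few compounds, and the source may have more. Where it says the series, first, only, none or still open, it means among the compounds named here.

Measured compounds:
compound 1, `N/C(=N\NC(=S)N1CCCCCC1)c1ccccn1`, 77.5%
compound 2, `N/C(=N\NC(=S)N1CCCCC1)c1ccccn1`, 85.6%
compound 3, `Cc1cccc(/C(N)=N/NC(=S)N2CCCCC2)n1`, 77.5%

Of the compounds shown here, three have been tested in a functional assay on A-431 cells (Homo sapiens) for cytotoxicity, read by MTT assay, with a stated time of 72 h, tested at 100 uM; a higher number here means more inhibition of growth at the concentration tested, a lower number less inhibition of growth. Compound 1 gives 77.5%. Compound 2 gives 85.6%. Compound 3 gives 77.5%. All three numbers lie within the scatter of one another, so no order among them can be claimed; compound 1 and compound 3 are level at the digits printed.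

Compound 2 and compound 3 differ in one place: methyl in place of hydrogen on an aromatic carbon. This change gave the step of a number 8.1 percentage points lower from compound 2 to compound 3 (within the scatter). Compound 1 and compound 2 differ in more than one place, and the difference between the two cores is not broken down here.

Compound 4, `Cc1cccc(/C(N)=N/NC(=S)N2CCCCCC2)n1`, has not yet been tested in this assay. It stands to compound 1 as compound 3 stands to compound 2: methyl in place of hydrogen on an aromatic carbon. The place of the change is described in the same words in both pairs, so this is the same change, occurring twice among the compounds shown.

The expectation for compound 4 rests on the earlier step because a number 8.1 percentage points lower from compound 2 to compound 3 (within the scatter) was within the scatter, and on the starting point of compound 1 because 77.5% is the value being changed. Compound 4 is therefore expected to show a step of about a number 5.5 percentage points lower from compound 1 to compound 4 (within the scatter), a small move beside the earlier one. The estimate for compound 4 in this assay is 72%, expected to fall between 55% and 86%.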

Compound 4, percent growth inhibition at one concentration: 76.7%
Beside the measured number, compound 4's estimate is 4.7 percentage points below it; low and high end bracket the measured number.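

In this assay, methyl in place of hydrogen on an aromatic carbon, next to the ring nitrogen, gave a number 0.8 percentage points lower from compound 1 to compound 4 (within the scatter) on the core of compound 1. Set beside the same change on the core of compound 2, the two steps do not differ: the same change on two cores in this assay, a number 8.1 percentage points lower (within the scatter) from compound 2 to compound 3 and a number 0.8 percentage points lower (within the scatter) from compound 1 to compound 4, 7.3 percentage points apart, within the scatter of two such steps. This shows that, in this assay and on these two cores, the change carried over without any step that stands out from the scatter, but it does not show that methyl has an effect of its own on growth inhibition on either core, and two pairs give no rule for any other core in the series.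

The compounds shown leave open whether another group in the same place, such as an ethyl chain, a methoxy group, an amine or a carboxylic acid, would give a step beyond the scatter on either core. They also leave open whether a difference between hydrogen and methyl would appear at lower concentrations, since every number here comes from a single tested concentration in this assay.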